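Trimethoxyphenyl pyrazole chalcones: aryl ketone variation

The source may hold more compounds than are shown below. What is called first, only, known or untested is meant among the compounds shown, and "the series" means these compounds.

Measured so far:
compound 1 `COc1cc(-c2cc(/C=C/C(=O)c3ccc(N)cc3)[nH]n2)cc(OC)c1OC`: 3510 nM
compound 2 `COc1ccc(-c2cc(/C=C/C(=O)c3ccc(OC)c(OC)c3)[nH]n2)cc1`: 3510 nM

In a functional assay on NCI-H226 cells (Homo sapiens) for inhibition, read by sulforhodamine B assay, with a stated time of 48 h (a lower number here means a stronger inhibitor of growth, a higher number a weaker inhibitor of growth), compound 1 gives 3510 nM and compound 2 gives 3510 nM; the two stand level within the scatter, so no order between them is claimed. Compound 3 `COc1cc(-c2cc(/C=C/C(=O)c3ccc(Cl)c(Cl)c3)[nH]n2)cc(OC)c1OC` is not yet measured. It differs from compound 1 in one place: 3,4-dichlorophenyl in place of 4-aminophenyl on a carbonyl carbon. Going by the values given here, no measured pair shows this change, so its effect is open. The step of a 1.0-fold lower number from compound 1 to compound 3 (0.00 log units; within the scatter) is expected to be small, with no direction beyond the scatter. Compound 3 is estimated at 3500 nM in this assay, within 1200 nM to 10000 nM.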

Compound 3, concentration for total growth inhibition: > 100000 nM
Compound 3 ended at the assay's limit; the forecaster's own chance of this, stated with the estimate: 5%; middle value at least 28-fold (1.45 log units) from the limit.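

Going by these compounds alone, this is the only step read on this carbonyl carbon, and there the aryl group is not interchangeable in this assay: 3,4-dichlorophenyl in place of 4-aminophenyl gives an at least 28-fold higher number from compound 1 to compound 3 (1.45 log units; beyond the scatter). Compound 3 stands at a limit of the assay, > 100000 nM, which is not a number. The step is a bound and not a measured size: the limit of > 100000 nM in this assay, at which 1 of the 3 values shown sits.

From the compounds shown here alone, whether the loss of the amine or the entry of the chlorine atoms carries the step stays open. Also open, going by these compounds, is how an unsubstituted phenyl, or a hydroxyl in place of the amine, would read in this assay.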